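The source may report more compounds than this note shows. Statements on the series, on what has been measured and on what is new or still open speak of the compounds shown alone.

Compound 1, `O=c1ccoc2cc(OCc3cn(Cc4ccccc4)nn3)ccc12`: in a functional assay on HeLa cells (Homo sapiens) for cytotoxicity, read by MTT assay, with a stated time of 48 h (on this read-out higher numbers stand for weaker inhibition and lower numbers for stronger inhibition), compound 1 reaches only the limit > 100000 nM.
Compound 2, `Cc1ccccc1Cn1cc(COc2ccc3c(=O)ccoc3c2)nn1`: in this assay compound 2 gives 15300 nM.
Compound 3, `O=c1ccoc2cc(OCc3cn(Cc4ccc(F)cc4)nn3)ccc12`: in this assay compound 3 gives 12000 nM.

Compound 2 holds the higher of the two numbers recorded in this assay, and its nearest neighbour is compound 3, with a 1.3-fold lower number from compound 2 to compound 3 (0.11 log units; within the scatter). The value of compound 1 is a limit of the assay, (the limit of > 100000 nM in this assay, at which 1 of the 3 values shown sits), not a number.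

The unmeasured compound 4, `O=c1ccoc2cc(OCc3cn(Cc4ccc([N+](=O)[O-])cc4)nn3)ccc12`, differs from compound 2 in one place: 4-nitrophenyl in place of 2-methylphenyl on a saturated chain carbon bound to an aromatic nitrogen. Going by the values given here, two measured steps bear on this change. From compound 1, the steps of an at least 6.5-fold lower number from compound 1 to compound 2 (0.81 log units; beyond the scatter) and an at least 8.3-fold lower number from compound 1 to compound 3 (0.92 log units; beyond the scatter) show that a substituent on the benzyl ring, whether methyl or fluoro, brings the number down from the limit. The step of a 1.3-fold lower number from compound 2 to compound 3 (0.11 log units; within the scatter) shows that exchanging one substituted benzyl ring for another moves the number little. The exchange from compound 2 to compound 4 is of the second kind, so no step beyond the scatter is expected in this assay. Compound 4 is therefore estimated at 10000 nM, with a range from 3000 nM to 40000 nM. This estimate means an expected step of a 1.5-fold lower number from compound 2 to compound 4 (0.18 log units; within the scatter).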

Compound 4, half-maximal inhibitory concentration: 25700 nM
Compound 4: the middle estimate sits 2.6-fold (0.41 log units) below what was measured; measured number inside the range.
By their numbers in this assay, from the lowest: compounds 3, 2 and 4 (each within the scatter of the next, the first and the last beyond it). At a limit, above all of these: compound 1.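

In this assay a third substituent on the benzyl ring, nitro, also brings the number down from the limit, with an at least 3.8-fold lower number from compound 1 to compound 4 (0.59 log units; beyond the scatter) as the step. The exchange of 2-methylphenyl for 4-nitrophenyl stays small, with a 1.7-fold higher number from compound 2 to compound 4 (0.23 log units; within the scatter) as its step, but nitro in place of fluoro gives a 2.1-fold higher number from compound 3 to compound 4 (0.33 log units; beyond the scatter) as a modest step, so the substituted benzyl rings are no longer all alike in this assay. The value of compound 1 remains a limit and not a number: the limit of > 100000 nM in this assay, at which 1 of the 4 values shown sits.

The compounds shown leave open whether the place of a group on the ring counts apart from the group itself, as only 2-methylphenyl, 4-fluorophenyl and 4-nitrophenyl appear. They also leave open what an amine or a carboxylic acid on the same ring would give.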